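Anilinopyrimidine nitriles with a triazole-linked acylurea tail

This account rests on a few compounds, and the source may have more. Where it says the series, first, only, none or still open, it means among the compounds named here.

Measured compounds in a functional assay on MCF7 cells (Homo sapiens) for inhibition, read by MTT assay, with a stated time of 72 h; a lower number here means a stronger inhibitor, a higher number a weaker inhibitor:
compound 1 `CC(C)c1ccc(-c2nc(SCc3cn(CC(=O)NC(=O)Nc4ccccn4)nn3)nc(Nc3cccc(Cl)c3)c2C#N)cc1`: 18000 nM
compound 3 `Cc1ccc(Nc2nc(SCc3cn(CC(=O)NC(=O)Nc4ccccn4)nn3)nc(-c3ccc(C)cc3)c2C#N)cc1`: 39600 nM
compound 2 `Cc1ccc(Nc2nc(SCc3cn(CC(=O)NC(=O)Nc4ccccn4)nn3)nc(-c3ccc(C(C)C)cc3)c2C#N)cc1`: a limit of the assay, not a number, namely > 64000 nM; this is the limit of > 64000 nM in this assay, at which 1 of the 3 values shown sits.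

Compound 4 `Cc1ccc(-c2nc(SCc3cn(CC(=O)NC(=O)Nc4ccccn4)nn3)nc(Nc3cccc(Cl)c3)c2C#N)cc1` is not yet measured in this assay.

The cores of compound 2 and compound 3 differ by methyl in place of isopropyl on an aromatic carbon, and that change gave an at least 1.6-fold lower number from compound 2 to compound 3 (0.20 log units; that floor lies within the scatter).

Compound 4 differs from compound 3 by 3-chlorophenyl in place of 4-methylphenyl on a nitrogen on an aromatic ring. The same change, at a place described in the same words, separates compound 2 from compound 1: 3-chlorophenyl in place of 4-methylphenyl on a nitrogen on an aromatic ring. There it gave an at least 3.5-fold lower number from compound 2 to compound 1 (0.55 log units; beyond the scatter), and because one end of that step is the limit of > 64000 nM in this assay, at which 1 of the 3 values shown sits, the full size of the step is not known.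

Compound 3 stands at the higher of the two numbers given. For compound 4 the expectation, resting on compound 1 and compound 2 and an at least 3.5-fold lower number from compound 2 to compound 1 (0.55 log units; beyond the scatter), is a step of a 4.4-fold lower number from compound 3 to compound 4 (0.64 log units; beyond the scatter). Compound 4 is therefore estimated at 9000 nM in this assay, within 3000 nM to 25000 nM.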

Compound 4, half-maximal inhibitory concentration: 14900 nM
Compound 4: middle estimate off by 1.7-fold (0.22 log units), on the low side; the range from low to high includes it.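

In this assay, 3-chlorophenyl in place of 4-methylphenyl on a nitrogen on an aromatic ring gives a 2.7-fold lower number from compound 3 to compound 4 (0.42 log units; beyond the scatter), so the direction seen on the core of compound 2 carries to the core of compound 3: the same change on two cores in this assay, an at least 3.5-fold lower number (0.55 log units; beyond the scatter) from compound 2 to compound 1 and a 2.7-fold lower number (0.42 log units; beyond the scatter) from compound 3 to compound 4; the limit leaves it open whether they differ

Compound 2 gives a limit of the assay, not a number, so the two steps show a shared direction but not a shared size.

The other change, methyl in place of isopropyl on an aromatic carbon, gives a 1.2-fold lower number from compound 1 to compound 4 (0.08 log units; within the scatter), so this pair shows no separable effect of that change, and comparison with the earlier step stays unresolved: the same change on two cores in this assay, an at least 1.6-fold lower number (0.20 log units; that floor lies within the scatter) from compound 2 to compound 3 and a 1.2-fold lower number (0.08 log units; within the scatter) from compound 1 to compound 4; the limit leaves it open whether they differ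

Two cores are a narrow basis, and they show nothing about how the step behaves on any other core. The compounds shown leave open whether the step persists with unsubstituted phenyl on that nitrogen, and whether it survives when a carboxylic acid replaces the acylurea tail.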